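A Methoxy for a Methyl on the Pendant Ring

This account rests on a few compounds, and the source may have more. Where it says the series, first, only, none or still open, it means among the compounds named here.

Compound 1 `CCOC(=O)c1cnc2scc(-c3ccc(CC)cc3)n12`: 24000 nM
Compound 2 `CCOC(=O)c1cnc2scc(-c3ccccc3)n12`: > 100000 nM (a limit of the assay, not a number)
Compound 3 `CCOC(=O)c1cnc2scc(-c3ccc(C)cc3)n12`: 18000 nM

Three compounds share one core and differ only in the group on the pendant six-membered ring. In an assay on isolated protein for inhibition of Indoleamine 2,3-dioxygenase 1 (Homo sapiens), with a stated time of 30 min (a lower number here means a stronger inhibitor, a higher number a weaker inhibitor), compound 1 gives 24000 nM. Compound 2 reaches only > 100000 nM, which is a limit of the assay and not a number (the limit of > 100000 nM in this assay, at which 1 of the 3 values shown sits). Compound 3 gives 18000 nM, the lowest of the two numbers shown; its nearest neighbour is compound 1, with a 1.3-fold lower number from compound 1 to compound 3 (0.12 log units; within the scatter). The steps to the unsubstituted ring are larger: an at least 4.1-fold higher number from compound 1 to compound 2 (0.61 log units; beyond the scatter) and an at least 5.5-fold lower number from compound 2 to compound 3 (0.74 log units; beyond the scatter).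

Compound 4 `CCOC(=O)c1cnc2scc(-c3ccc(OC)cc3)n12` is not yet measured. The change is methoxy in place of methyl on an aromatic carbon. Within the data shown here, two measured steps bear on it. The exchange of ethyl for methyl gave a 1.3-fold lower number from compound 1 to compound 3 (0.12 log units; within the scatter), so a small carbon group of either size behaves alike. Loss of the group entirely gave an at least 5.5-fold lower number from compound 2 to compound 3 (0.74 log units; beyond the scatter), so an occupied position matters. Among the measured compounds shown here, no measured step brings in an oxygen-bearing group, so the direction is uncertain. For compound 4 the expected step is a 1.1-fold higher number from compound 3 to compound 4 (0.05 log units; within the scatter), within the scatter. Compound 4 is therefore estimated at 20000 nM, between 6000 nM and 70000 nM.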

Compound 4, half-maximal inhibitory concentration: 56000 nM
Estimate against measurement, compound 4: 2.8-fold (0.45 log units) below; measured number inside the range.
By their numbers in this assay, from the lowest: compounds 3 and 1 (each within the scatter of the next); then compound 4. At a limit, above all of these: compound 2.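

In this assay this position proved sensitive to which group occupies it, not only to whether it is occupied: methoxy in place of methyl gave a 3.1-fold higher number from compound 3 to compound 4 (0.49 log units; beyond the scatter), and methoxy in place of ethyl gave a 2.3-fold higher number from compound 1 to compound 4 (0.37 log units; beyond the scatter). Methoxy, the only oxygen-bearing group on the pendant ring among these compounds, therefore gives a higher number than either carbon group, while those two stay within the scatter of each other. Any gain over the unsubstituted ring remains unproven, with an at least 1.7-fold lower number from compound 2 to compound 4 (0.25 log units; that floor lies within the scatter), and the value of compound 2 is a limit of the assay, not a number: the limit of > 100000 nM in this assay, at which 1 of the 4 values shown sits.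

As far as these compounds go, whether a hydroxyl group, an amine or a chlorine atom in this place would behave like methyl or like methoxy remains open. So does whether a longer chain, such as propyl, would hold the number of compound 3.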